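Methoxy in Place of Fluoro: An Expected Small Step

The source may report more compounds than this note shows. Statements on the series, on what has been measured and on what is new or still open speak of the compounds shown alone.

Compound 1 `CCN(Cc1cccs1)C(=O)COc1ccc(F)cc1`: 422 nM
Compound 2 `CCN(Cc1cn[nH]c1)C(=O)COc1ccc(C)cc1`: "active" (no number reported)
Compound 3 `Cc1ccc(OCC(=O)N(Cc2cccs2)c2cn[nH]c2)cc1`: 1.4 nM

Three compounds were measured in an assay on HEK293 cells for agonist activity at transient receptor potential cation channel subfamily M member 8 (Homo sapiens), read by fluorescence and calcium flux, with a stated time of 15 min; on this read-out lower numbers stand for an effect already at smaller amounts and higher numbers for an effect only at larger amounts of compound. Compound 1 gives 422 nM, the higher of the two numbers reported. Its nearest neighbour by value is compound 3, which gives 1.4 nM, a gap far beyond the usual scatter; the two compounds differ in more than one place, so what separates them cannot be assigned to any single change. Compound 2 is reported only as "active" (no number reported), with no number attached.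

Compound 4 `CCN(Cc1cccs1)C(=O)COc1ccc(OC)cc1` has not yet been measured. It differs from compound 1 in one place: methoxy in place of fluoro on an aromatic carbon. Among the compounds with values here, no pair among the measured compounds isolates this exchange, so nothing in the data shows how a methoxy compares with a fluoro on this aromatic carbon. Compound 3 carries a methyl at the same kind of position but also a different amide substituent, so it offers no clean comparison.

In the absence of a guiding step, compound 4 is expected to stay close to compound 1, with a step of a 1.2-fold lower number from compound 1 to compound 4 (0.08 log units; within the scatter), a change not clearly beyond the scatter. Compound 4 is therefore estimated at 350 nM, within a range of 100 nM to 1300 nM in this assay.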

Compound 4, half-maximal effective concentration: 120 nM
The estimate for compound 4 lay 2.9-fold (0.46 log units) above the measured number; the range from low to high includes it.
By their numbers in this assay, from the lowest: compound 3; then compound 4; then compound 1.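

Methoxy in place of fluoro on this aromatic carbon, para to a large group, is the first exchange in the series that changes this position alone, and in this assay it gives a 3.5-fold lower number from compound 1 to compound 4 (0.55 log units; beyond the scatter). This shows that the number responds to what sits at this position while the rest of the molecule stays fixed; the step is modest but beyond the scatter, and in this single pair the lower number goes with the group that brings one more heavy atom and one hydrogen-bond acceptor. No measurement shown here explains the difference between the two groups.

The compounds shown leave open whether the lower number follows from the oxygen, from the added carbon or from the two together, and how an amine, a hydroxyl, a chlorine or a longer chain such as ethoxy would read at this aromatic carbon. They also leave open whether methoxy in place of fluoro would give a step of similar size on a core carrying the amide substituents of compound 3.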